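Replacing Ethylamino on the Carbonyl of Compound 3

The source may report more compounds than this note shows. Statements on the series, on what has been measured and on what is new or still open speak of the compounds shown alone.

The three measured compounds share one core and are read out in a functional assay on the whole organism for inhibition of sodium-dependent dopamine transporter (Mus musculus); a higher number here means that more compound is needed for the effect, a lower number that less compound is needed. Compound 1 `Cc1ccc(C2CN(C)Cc3c(N)cccc32)cc1` gives about 22 mg/kg in this assay. Among the compounds with values here, compound 2 `CC(C)c1ccc(C2CN(C)Cc3c(N)cccc32)cc1` gives about 65 mg/kg, and the step of a 3.0-fold higher number from compound 1 to compound 2 (0.47 log units; beyond the scatter) is the only measured step between compounds that differ in one place. Compound 3 `CCNC(=O)Nc1cccc2c1CN(C)CC2c1ccccc1` stands apart: in this assay compound 3 reaches only a limit, > 80 mg/kg, which is not a number. That limit is the one described by the limit of > 80 mg/kg in this assay, at which 1 of the 3 values shown sits.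

Compound 4 `CCCCNCC(=O)Nc1cccc2c1CN(C)CC2c1ccccc1` differs from compound 3 only in (butylamino)methyl in place of ethylamino on a carbonyl carbon. Within the data shown here, no measured step touches the group on the carbonyl carbon; the single step, from methyl to isopropyl on an aromatic carbon, was modest and bears on a different part of the molecule. Compound 3 itself offers only a limit as a starting point. The expectation is therefore that compound 4 also sits at or near the limit in this assay, with no step beyond the scatter discernible, the estimated step being a step that the limit leaves unreadable from compound 3 to compound 4. Compound 4 is expected to give about 110 mg/kg in this assay, within a range from 40 mg/kg to 300 mg/kg.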

Compound 4, dose for half-maximal effect: 25 mg/kg
Compound 4: the middle estimate sits 4.4-fold (0.64 log units) above what was measured; the whole stated range lies above it.
By their numbers in this assay, from the lowest: compounds 1 and 4 (each within the scatter of the next); then compound 2. At a limit, above all of these: compound 3.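

In this assay, the group on the carbonyl carbon proves able to move the read-out: (butylamino)methyl in place of ethylamino gives an at least 3.2-fold lower number from compound 3 to compound 4 (0.50 log units; beyond the scatter). Within the data shown here, this is the first measured step at this position, since the earlier step concerned a different place, an aromatic carbon. Compound 3 stands at a limit, so this step gives only a minimum size and its true extent stays unknown: the limit of > 80 mg/kg in this assay, at which 1 of the 4 values shown sits.

The compounds shown leave open whether the change follows the amine nitrogen in the entering group or the longer chain, which a plain pentyl chain or a shorter (methylamino)methyl group on the same carbonyl carbon would help to separate. They also leave open how a carboxylic acid at the end of the chain, or a tertiary amine in place of the butylamino nitrogen, would read in this position.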